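The source may report more compounds than this note shows. Statements on the series, on what has been measured and on what is new or still open speak of the compounds shown alone.

In a functional assay on HeLa cells (Homo sapiens) for cytotoxicity, read by MTT assay (a higher number here means a weaker inhibitor, a lower number a stronger inhibitor), compound 1 (`CC(=O)OCCO[C@H](CC=C(C)C)C1=CC(=O)c2c(O)ccc(O)c2C1=O`) gives 41500 nM and compound 2 (`CC[C@](C)(O)CC(=O)O[C@H](CC=C(C)C)C1=CC(=O)c2c(O)ccc(O)c2C1=O`) gives 30200 nM while compound 3 (`CC(C)=CC[C@@H](OCCO)C1=CC(=O)c2c(O)ccc(O)c2C1=O`) gives 18600 nM as the reference point here. That reference point is placed by a 1.6-fold lower number from compound 2 to compound 3 (0.21 log units; within the scatter) and by a 2.2-fold lower number from compound 1 to compound 3 (0.35 log units; beyond the scatter) with hydrogen in place of acetyl. Compound 4 (`CCC(CO[C@H](CC=C(C)C)C1=CC(=O)c2c(O)ccc(O)c2C1=O)OC`) carries 1-methoxypropyl in place of hydroxymethyl on a saturated chain carbon bound to an oxygen on a saturated carbon with 1-methoxypropyl in place of hydroxymethyl, so the entering group has no hydrogen-bond donor. Going by the values given here, the acetyl step is the only measured step beyond the scatter that bears on this, and no methyl ether has been measured. A modest rise in the number is therefore expected (a 1.6-fold higher number from compound 3 to compound 4 (0.21 log units; within the scatter)) in this assay with little confidence. Compound 4 is estimated at 30000 nM (expected range 14000 nM to 60000 nM).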

Compound 4, half-maximal inhibitory concentration: 63500 nM
Compound 4: the middle estimate sits 2.1-fold (0.33 log units) below what was measured; measured number above the stated range.
By their numbers in this assay, from the lowest: compounds 3, 2, 1 and 4 (each within the scatter of the next, the first and the last beyond it).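

In this assay, 1-methoxypropyl in place of hydroxymethyl on a saturated chain carbon bound to an oxygen on a saturated carbon gives a 3.4-fold higher number from compound 3 to compound 4 (0.53 log units; beyond the scatter), so this position responds to a change beyond the acetyl step. The 2-methoxybutyl side chain also separates from the ester side chain, with a 2.1-fold higher number from compound 2 to compound 4 (0.32 log units; beyond the scatter), but not from the acetoxymethyl variant, with a 1.5-fold higher number from compound 1 to compound 4 (0.18 log units; within the scatter). No measured evidence bears on the origin of these steps.

This change alters chain size and removes the hydroxyl together, so their shares stay unresolved. Methoxymethyl, an amine or a carboxylic acid here remains open.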